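This account rests on a few compounds, and the source may have more. Where it says the series, first, only, none or still open, it means among the compounds named here.

Series notes. Compound 1 `CC(O)(CSc1ccc(S(F)(F)(F)(F)F)cc1)C(=O)Nc1ccc(C#N)cc1C(F)(F)F` is the thioether with a nitrile on the anilide ring; in a functional assay on DU-145 cells (Homo sapiens) for antiproliferative activity, read by propidium iodide staining, with a stated time of 96 h (a lower number here means a stronger inhibitor, a higher number a weaker inhibitor), compound 1 gives 17700 nM. Compound 2 `CC(O)(CSc1ccc(S(F)(F)(F)(F)F)cc1)C(=O)Nc1ccc([N+](=O)[O-])cc1C(F)(F)F` carries nitro in place of cyano on an aromatic carbon and in this assay compound 2 gives 14500 nM; the step is a 1.2-fold lower number from compound 1 to compound 2 (0.09 log units; within the scatter). Compound 3 `CC(O)(CS(=O)(=O)c1ccc(S(F)(F)(F)(F)F)cc1)C(=O)Nc1ccc(C#N)cc1C(F)(F)F` is the sulfone analogue of compound 1 with the nitrile retained; the difference between the two cores is not broken down here. In this assay compound 3 gives 25600 nM, a number that sits within the scatter of both compound 1 and compound 2, so no ordering among the three is claimed.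

Compound 4 `CC(O)(CS(=O)(=O)c1ccc(S(F)(F)(F)(F)F)cc1)C(=O)Nc1ccc([N+](=O)[O-])cc1C(F)(F)F` has not been measured. Relative to compound 3 it carries nitro in place of cyano on an aromatic carbon, the same change already seen from compound 1 to compound 2, at the same place. The expected step from compound 3 to compound 4 in this assay is a 1.2-fold lower number from compound 3 to compound 4 (0.09 log units; within the scatter), which rests on the step from compound 1 to compound 2, a 1.2-fold lower number from compound 1 to compound 2 (0.09 log units; within the scatter), being small. Compound 4 is therefore estimated at 21000 nM, with an expected range from 10000 nM to 45000 nM.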

Compound 4, half-maximal inhibitory concentration: 17700 nM
Compound 4: the middle estimate sits 1.2-fold (0.07 log units) above what was measured, and the stated range covers the measured number.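

In this assay, nitro in place of cyano on an aromatic carbon, carried onto the core of compound 3, gives a 1.4-fold lower number from compound 3 to compound 4 (0.16 log units; within the scatter). Set beside the earlier pair, the change reads the same on both cores: the same change on two cores in this assay, a 1.2-fold lower number (0.09 log units; within the scatter) from compound 1 to compound 2 and a 1.4-fold lower number (0.16 log units; within the scatter) from compound 3 to compound 4, 1.2-fold (0.07 log units) apart, within the scatter of two such steps. For the compounds shown here, this shows that the exchange of nitrile for nitro carries across these two cores without a detectable difference, but it does not show that the exchange has any effect of its own on either core, and with only two pairs in one assay it says nothing about cores beyond these.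

The compounds shown leave open whether any other group at the same place, such as an amine, a carboxylic acid or a plain hydrogen, would move the number beyond the scatter. Also open, on these data alone, is whether a sulfoxide in place of the thioether or sulfone, or a chlorine in place of the trifluoromethyl group, would do so.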